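Amine variation at a saturated ring carbon

The compounds below may be only part of what the source reports. "The series", "measured", "known", "first", "only" and "open" are said of these compounds alone.

The three measured compounds share one core and differ only in the amine on a saturated ring carbon. Compound 1 `CCN(CC)C1CCC(COCc2cc(C(F)(F)F)cc(C(F)(F)F)c2)(c2ccccc2)CC1` gives 38 nM in an assay on isolated protein for antagonist activity at Substance-P receptor (Homo sapiens); a higher number here means a weaker inhibitor, a lower number a stronger inhibitor; compound 2 `CN(C)C1CCC(COCc2cc(C(F)(F)F)cc(C(F)(F)F)c2)(c2ccccc2)CC1` gives 48 nM in this assay; compound 3 `FC(F)(F)c1cc(COCC2(c3ccccc3)CCC(NC3CC3)CC2)cc(C(F)(F)F)c1` gives 74 nM in this assay. Compound 3 stands at the highest of the three numbers, yet a 1.9-fold higher number from compound 1 to compound 3 (0.29 log units; within the scatter) and a 1.5-fold higher number from compound 2 to compound 3 (0.19 log units; within the scatter) both lie within the scatter, as does a 1.3-fold higher number from compound 1 to compound 2 (0.10 log units; within the scatter), so no order among the three is claimed.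

Compound 4 `FC(F)(F)c1cc(COCC2(c3ccccc3)CCC(N3CCCCC3)CC2)cc(C(F)(F)F)c1` carries the change (piperidin-1-yl in place of cyclopropylamino on a saturated ring carbon). The two steps that bear on it are those from compound 1 and compound 2 to compound 3, where dimethylamino or diethylamino was exchanged for cyclopropylamino without a step beyond the scatter. Going back from cyclopropylamino to a ring-closed amine is therefore expected to give no step beyond the scatter in this assay, and the expected step is a 1.6-fold lower number from compound 3 to compound 4 (0.22 log units; within the scatter). Compound 4 is estimated at 45 nM, with a range from 20 nM to 110 nM.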

Compound 4, half-maximal inhibitory concentration: 93 nM
Compound 4: the middle estimate sits 2.1-fold (0.32 log units) below what was measured; the measured number falls inside the stated range.
By their numbers in this assay, from the lowest: compounds 1, 2, 3 and 4 (each within the scatter of the next, the first and the last beyond it).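

In this assay, piperidin-1-yl in place of cyclopropylamino gives a 1.3-fold higher number from compound 3 to compound 4 (0.10 log units; within the scatter), and in place of dimethylamino it gives a 1.9-fold higher number from compound 2 to compound 4 (0.29 log units; within the scatter), so the ring-closed amine separates from neither group, even though the exchange from cyclopropylamino removes a hydrogen-bond donor. Among these compounds, only the exchange for diethylamino separates, with a 2.4-fold higher number from compound 1 to compound 4 (0.39 log units; beyond the scatter), the first step in this set beyond the scatter, and a modest one. No measurement on hand explains that single step.

The compounds shown leave open whether a basic nitrogen is needed on this saturated ring carbon at all, which a hydroxyl group or an amide there would address. They also leave open whether a morpholin-4-yl ring or a primary amine would stay within the same narrow band of values.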